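Replacing 3,4-dimethoxyphenyl with 4-fluorophenyl on a growth inhibitor

The source may report more compounds than this note shows. Statements on the series, on what has been measured and on what is new or still open speak of the compounds shown alone.

Among the measured compounds shown here, in a functional assay on HOP-62 cells (Homo sapiens) for inhibition, read by sulforhodamine B assay (a lower number here means a stronger inhibitor of growth, a higher number a weaker inhibitor of growth), compound 1 (`COc1ccc(-c2ccc(-c3ccc(-c4nc5cc(C)ccc5[nH]4)cc3)cc2)cc1OC`) gives 2120 nM and compound 2 (`COc1ccc(-c2ccc(-c3ccc(-c4nc5ccccc5[nH]4)cc3)cc2)cc1OC`) gives 4200 nM as the only two numbers so far. These two values lie within the scatter of each other, so compound 1 holds no clear rank. For the measured compounds named here, the one measured step has hydrogen in place of methyl on an aromatic carbon and amounts to a 2.0-fold higher number from compound 1 to compound 2 (0.30 log units; within the scatter) in a comparison that leaves the 3,4-dimethoxyphenyl group untouched. Compound 3 (`Cc1ccc2[nH]c(-c3ccc(-c4ccc(-c5ccc(F)cc5)cc4)cc3)nc2c1`) has 4-fluorophenyl in place of 3,4-dimethoxyphenyl on an aromatic carbon, para to a large group (4-fluorophenyl in place of 3,4-dimethoxyphenyl on an aromatic carbon). No measured step covers this exchange, so the data give no direction for it and no reason to expect a shift beyond the scatter. Starting from compound 1 at 2120 nM with that single small step as the only guide, the expected change is a 1.2-fold higher number from compound 1 to compound 3 (0.07 log units; within the scatter) and the uncertainty stays wide. Compound 3 is estimated at 2500 nM with an expected range from 800 nM to 8000 nM in this series.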

Compound 3, concentration for 50% growth inhibition: 33500 nM
Compound 3: the middle estimate sits 13-fold (1.13 log units) below what was measured; measured number above the stated range.
By their numbers in this assay, from the lowest: compounds 1 and 2 (each within the scatter of the next); then compound 3.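

In this assay, the place on the aromatic carbon para to a large group proves sensitive to what it carries: 4-fluorophenyl in place of 3,4-dimethoxyphenyl gives a 16-fold higher number from compound 1 to compound 3 (1.20 log units; beyond the scatter) as a large step beyond the scatter. Among the compounds shown here, the only earlier step, hydrogen in place of methyl (described as a 2.0-fold higher number from compound 1 to compound 2 (0.30 log units; within the scatter)), left the 3,4-dimethoxyphenyl group untouched and so said nothing about this place; the new step shows that the group cannot be exchanged for 4-fluorophenyl without a clear cost in growth inhibition, at least on the core of compound 1. The exchange goes from 10 heavy atoms to 7 and from 2 hydrogen-bond acceptors to 0 while also bringing in fluorine, and no evidence is at hand that ties the step to any one of these differences.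

The compounds shown leave open whether the loss of the two methoxy groups or the arrival of the fluorine accounts for the step, and how a 4-methoxyphenyl, 3-methoxyphenyl or 4-aminophenyl group would stand at this place. They also leave open whether hydrogen in place of methyl on the shared core behaves the same way once 4-fluorophenyl is present.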